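The source may hold more compounds than are shown below. What is called first, only, known or untested is meant among the compounds shown, and "the series" means these compounds.

Measured in an assay on cells with melanin-concentrating hormone receptor 1 (Homo sapiens) as the target, read by radioligand binding; a higher number here means a weaker inhibitor, a lower number a stronger inhibitor:
compound 1 `CC(CNC1CCCC1)Oc1cccc2ccc(N)nc12` gives 30 nM
compound 2 `CC(CN1CCCC1)Oc1cccc2ccc(N)nc12` gives 70 nM
compound 3 `CC(CNc1ccc2[nH]ncc2c1)Oc1cccc2ccc(N)nc12` gives 530 nM

Compound 2 stands second highest of the three numbers; nearest is compound 1, furthest compound 3. Among the compounds with values here, the single measured step that touches it, a 2.3-fold higher number from compound 1 to compound 2 (0.37 log units; beyond the scatter), closes a secondary amine into a ring and costs a modest amount. Within the data shown here, compound 4 `CC(CNCc1ccoc1)Oc1cccc2ccc(N)nc12` differs from compound 2 by ((furan-3-yl)methyl)amino in place of pyrrolidin-1-yl on a saturated chain carbon, two bonds along the chain from an oxygen on an aromatic ring, so the secondary amine returns, now carrying an aromatic substituent; no measured step covers that exact change, and compound 3, with an aromatic group directly on the amine, gives a clearly higher number than compound 1. The expected step is small, toward a lower number: a 1.3-fold lower number from compound 2 to compound 4 (0.10 log units; within the scatter). Compound 4 is estimated at 55 nM in this assay, with a range of 20 nM to 200 nM.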

Compound 4, half-maximal inhibitory concentration: 10 nM
Compound 4: middle estimate off by 5.5-fold (0.74 log units), on the high side; the measured number lies below the stated range.
By their numbers in this assay, from the lowest: compound 4; then compound 1; then compound 2; then compound 3.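

In this assay, the secondary amine on this saturated chain carbon accepts an aromatic substituent and still reaches the lowest number of the four compounds, both against the closed ring (a 7.0-fold lower number from compound 2 to compound 4 (0.85 log units; beyond the scatter)) and against the saturated ring on the same nitrogen (a 3.0-fold lower number from compound 1 to compound 4 (0.48 log units; beyond the scatter)). Aromatic character on this nitrogen therefore does not by itself bring a high number, as compound 3 (530 nM) alone might have suggested. No evidence bears on the cause of these steps. Left open is whether a benzyl or (thiophen-3-yl)methyl group would match the (furan-3-yl)methyl group. Also open, from the compounds shown here alone, is how a longer chain between the amine nitrogen and the furan ring would read.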